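One Aryl Swap on a Shared Core

This account rests on a few compounds, and the source may have more. Where it says the series, first, only, none or still open, it means among the compounds named here.

Of the compounds shown here, three built on one shared core have been tested in a functional assay on MKN-45 cells (Homo sapiens) for cytotoxicity, read by MTT assay, with a stated time of 72 h; on this read-out lower numbers stand for stronger inhibition and higher numbers for weaker inhibition. Compound 1 `COc1ccc(OC)c(/C=N/NC(=O)Nc2ccc(Oc3ccnc(-c4nncn4CCN(C)C)c3)c(F)c2)c1` gives 1510 nM, the lowest of the three numbers. Compound 2 `CN(C)CCn1cnnc1-c1cc(Oc2ccc(NC(=O)N/N=C/c3ccccc3)cc2F)ccn1` gives 2730 nM in this assay, and compound 3 `CN(C)CCn1cnnc1-c1cc(Oc2ccc(NC(=O)N/N=C/c3ccc(O)c(O)c3)cc2F)ccn1` gives 3240 nM. The step of a 1.8-fold higher number from compound 1 to compound 2 (0.26 log units; within the scatter) stays inside the usual scatter, whereas a 2.1-fold higher number from compound 1 to compound 3 (0.33 log units; beyond the scatter) is modest but goes beyond it; between the two, a 1.2-fold higher number from compound 2 to compound 3 (0.07 log units; within the scatter) is again inside the scatter.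

Compound 4 `CN(C)CCn1cnnc1-c1cc(Oc2ccc(NC(=O)N/N=C/c3c(O)ccc4ccccc34)cc2F)ccn1` differs from compound 1 in one place: 2-hydroxynaphthalen-1-yl in place of 2,5-dimethoxyphenyl on a carbon with a double bond to nitrogen. For the measured compounds named here, two measured steps bear on this change, since both also replace the 2,5-dimethoxyphenyl: a 1.8-fold higher number from compound 1 to compound 2 (0.26 log units; within the scatter) and a 2.1-fold higher number from compound 1 to compound 3 (0.33 log units; beyond the scatter). Both gave somewhat higher numbers, so for compound 4 a small rise, at most modest, is expected rather than a fall. Going by the values given here, the 2-hydroxynaphthalen-1-yl group itself has no measured counterpart here, so the range is kept wide. Compound 4 is therefore estimated at 2500 nM, with a range from 1000 nM to 6500 nM. The expected step is a 1.7-fold higher number from compound 1 to compound 4 (0.22 log units; within the scatter).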

Compound 4, half-maximal inhibitory concentration: 2020 nM
For compound 4 the middle estimate is 1.2-fold (0.09 log units) above the measured one; low and high end bracket the measured number.
By their numbers in this assay, from the lowest: compounds 1, 4, 2 and 3 (each within the scatter of the next, the first and the last beyond it).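

In this assay the 2-hydroxynaphthalen-1-yl group on this carbon with a double bond to nitrogen sits close to all three earlier groups: a 1.3-fold higher number from compound 1 to compound 4 (0.13 log units; within the scatter) and a 1.4-fold lower number from compound 2 to compound 4 (0.13 log units; within the scatter) and also a 1.6-fold lower number from compound 3 to compound 4 (0.21 log units; within the scatter) are each within the scatter. Going from one six-membered aromatic ring to two, and from 0 hydrogen-bond donors to 1, therefore brings no change here that can be told apart from the scatter of compound 1. Nothing available explains where these numbers fall.

All four groups at this position are aromatic rings of carbon only, so a pyridine ring, an amine or a plain alkyl chain remains untested among the compounds shown. As far as these compounds go, whether any group here could move the number far from these four also stays open.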